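The source may report more compounds than this note shows. Statements on the series, on what has been measured and on what is new or still open speak of the compounds shown alone.

In an ADME assay on Vero cells (Chlorocebus sabaeus) for cytotoxicity, read by reporter gene assay, with a stated time of 4 days (on this read-out higher numbers stand for weaker inhibition and lower numbers for stronger inhibition), three esters built on a shared core have been measured. Compound 1 (`CCCCCC(=O)OCC(C)(C)CC1=C(O)C(=O)c2ccccc2C1=O`) gives 169000 nM, and compound 3 (`CCCCCCCCCCCC(=O)OCC(C)(C)CC1=C(O)C(=O)c2ccccc2C1=O`) gives 249000 nM. For compound 2 (`CCCCCCCC(=O)OCC(C)(C)CC1=C(O)C(=O)c2ccccc2C1=O`) the assay returns only a limit, > 258000 nM. Compound 3 therefore stands level with compound 1, since the step of a 1.5-fold higher number from compound 1 to compound 3 (0.17 log units; within the scatter) lies within the scatter, and it has no measured neighbour beyond that scatter.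

Compound 4 (`CCCCCCCCCCCCCC(=O)OCC(C)(C)CC1=C(O)C(=O)c2ccccc2C1=O`) departs from compound 3 by one change: ethyl in place of hydrogen on a saturated chain carbon, ten or more bonds along the chain from a carbonyl carbon. That is ethyl in place of hydrogen on a saturated chain carbon, ten or more bonds along the chain from a carbonyl carbon. Among the compounds with values here, three measured steps bear on it. The closest in kind is the same ethyl change made five bonds along the chain, the step of an at least 1.5-fold higher number from compound 1 to compound 2 (0.18 log units; that floor lies within the scatter), whose floor lies within the scatter. The butyl change seven bonds along, the step of an at least 1.0-fold lower number from compound 2 to compound 3 (0.01 log units; that floor lies within the scatter), also has a floor within the scatter, and the hexyl step already cited stays within it too. In this assay, no size or direction of change beyond the scatter is therefore expected. The expected step is a 1.0-fold higher number from compound 3 to compound 4 (0.00 log units; within the scatter), and a limit instead of a number would not be surprising. Compound 4 is estimated at 250000 nM, with an expected range from 125000 nM to 500000 nM.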

Compound 4, half-maximal inhibitory concentration: 58400 nM
Compound 4: the middle estimate sits 4.3-fold (0.63 log units) above what was measured; the whole stated range lies above it.
By their numbers in this assay, from the lowest: compound 4; then compounds 1 and 3 (each within the scatter of the next). At a limit, above all of these: compound 2.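

In this assay, within the data shown here, the newly measured ethyl change gives the first step to pass beyond the scatter: a 4.3-fold lower number from compound 3 to compound 4 (0.63 log units; beyond the scatter). The two longer changes ending in the same chain also pass beyond it, the hexyl change seven bonds along with an at least 4.4-fold lower number from compound 2 to compound 4 (0.64 log units; beyond the scatter) and the octyl change five bonds along with a 2.9-fold lower number from compound 1 to compound 4 (0.46 log units; beyond the scatter), so the earlier level reading among the shorter esters does not extend to compound 4. The ethyl change therefore does not read the same at every place along the chain, and its outcome differs between the two places measured: the same change on two cores in this assay, an at least 1.5-fold higher number (0.18 log units; that floor lies within the scatter) from compound 1 to compound 2 and a 4.3-fold lower number (0.63 log units; beyond the scatter) from compound 3 to compound 4, at least 6.5-fold (0.81 log units) apart, beyond the scatter of two such steps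

From the compounds shown here alone, compound 2 remains a limit, > 258000 nM, and its actual number stays open. The compounds shown also leave open whether a longer chain would take the number lower still, and whether an amine or a carboxylic acid at the end of the chain would give a similar reading.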